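A few compounds are considered here, and "the series" means these few. Any claim that something is new, unique, unknown or untested is made for them only; others in the source may bear on it.

In an ADME assay on THLE-2 cells (Homo sapiens) for cytotoxicity, read by luminescence, with a stated time of 72 h (a lower number here means that less compound is tolerated, a higher number that more compound is tolerated), compound 1 `CNC(=O)NC(=O)C1(S(=O)(=O)c2ccc(Oc3ccc(OC(F)(F)F)cc3)cc2)CCC2(CCNCC2)C1` gives 16200 nM and compound 2 `Nc1ccc(-c2ccccc2)cc1NC(=O)C1(S(=O)(=O)c2ccc(Oc3ccc(OC(F)(F)F)cc3)cc2)CCC2(CCNCC2)C1` gives 3530 nM as the lower of the two numbers, a gap beyond the scatter. Compound 3 `Nc1ccc(-c2cccs2)cc1NC(=O)C1(S(=O)(=O)c2ccc(Oc3ccc(OC(F)(F)F)cc3)cc2)CCC2(CCNCC2)C1` carries thiophen-2-yl in place of phenyl on an aromatic carbon and is otherwise the same as compound 2. Among the compounds with values here, no measured pair shows this change, so the expectation rests on compound 2 at 3530 nM alone, and no step beyond the scatter is expected in this assay in either direction. The expected change is a 1.1-fold higher number from compound 2 to compound 3 (0.03 log units; within the scatter) and lies within the scatter. For compound 3 the estimated value is 3800 nM with 1900 nM to 7500 nM as its expected range.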

Compound 3, concentration lethal to 50% of the cells: 2800 nM
Estimate against measurement, compound 3: 1.4-fold (0.13 log units) above, and the stated range covers the measured number.
By their numbers in this assay, from the lowest: compounds 3 and 2 (each within the scatter of the next); then compound 1.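

In this assay, thiophen-2-yl in place of phenyl on this aromatic carbon, para to an amino group, gives a 1.3-fold lower number from compound 2 to compound 3 (0.10 log units; within the scatter), so this exchange of one aromatic ring for another leaves the number within the scatter. The 2-amino-5-(thiophen-2-yl)phenyl group in place of methylcarbamoyl on the amide-type nitrogen gives a 5.8-fold lower number from compound 1 to compound 3 (0.76 log units; beyond the scatter), a step beyond the scatter, as the phenyl-bearing compound 2 already suggested. Nothing measured here accounts for either step.

As far as these compounds go, whether a furan or pyridine ring at this position would also stay within the scatter of compound 2 remains open. So does the effect of a carboxylic acid or an amine on the thiophen-2-yl ring.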